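A methyl on the nitrogen of compound 2

The compounds below may be only part of what the source reports. "The series", "measured", "known", "first", "only" and "open" are said of these compounds alone.

In an ADME assay on microsomes from liver (Rattus norvegicus) for metabolic stability, read by LC-MS, using NADPH, with a stated time of 60 min (a lower number here means slower removal, a higher number faster removal of the compound), compound 1 `Fc1ccc2[nH]c(Cc3c[nH]c4c(F)cccc34)cc2c1` gives 60.7 mL.min-1.g-1 while compound 2 `O=C(c1nc2ccc(F)cc2[nH]1)c1c[nH]c2c(F)cccc12` gives 29.4 mL.min-1.g-1 and compound 3 `O=C(c1cc2cc(F)ccc2[nH]1)c1c[nH]c2c(F)cccc12` gives 18.1 mL.min-1.g-1 as its number. Compound 2 lies within the usual scatter of compound 3, whereas compound 1 is removed faster, beyond that scatter.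

Compound 4 `Cn1c(C(=O)c2c[nH]c3c(F)cccc23)nc2ccc(F)cc21`, not yet measured, has methyl in place of hydrogen on an aromatic nitrogen of compound 2 (methyl in place of hydrogen on an aromatic nitrogen). Going by the values given here, no measured pair shows this change, which leaves any forecast loose. A small rise in this assay is expected, one that stays within the scatter. The estimated step of a 1.4-fold higher number from compound 2 to compound 4 (0.13 log units; within the scatter) is modest and upward. For compound 4 the estimated value is 40 mL.min-1.g-1 with an expected range of 17 mL.min-1.g-1 to 90 mL.min-1.g-1 in this measurement.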

Compound 4, intrinsic clearance in microsomes: 23 mL.min-1.g-1
Compound 4: the middle estimate sits 1.7-fold (0.24 log units) above what was measured; the measured number falls inside the stated range.
By their numbers in this assay, from the lowest: compounds 3, 4 and 2 (each within the scatter of the next); then compound 1.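

In this assay, methyl in place of hydrogen on an aromatic nitrogen gives a 1.3-fold lower number from compound 2 to compound 4 (0.11 log units; within the scatter), so at this position the swap leaves removal indistinguishable from that of the parent. This is the only pair shown that differs in one place, and it gives the first direct reading of any change on this core. No supporting measurement here accounts for the result.
On these data alone, whether an ethyl or a longer chain ending in an amine would be tolerated on this nitrogen stays open. So does whether methyl would give a similar step on compound 3.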